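The source may report more compounds than this note shows. Statements on the series, on what has been measured and on what is new or still open speak of the compounds shown alone.

Compound 1 `Nc1nc2c(ncn2[C@@H]2O[C@H](CO)[C@@H](O)[C@H]2O)/c(=N\O)[nH]1`: 281000 nM in a functional assay on KB cells (Homo sapiens) for cytotoxicity; a lower number here means that less compound is tolerated, a higher number that more compound is tolerated
Compound 2 `CO/N=c1/[nH]cnc2c1ncn2[C@@H]1O[C@H](CO)[C@@H](O)[C@H]1O`: 6160 nM in this assay

Compound 2 gives the lowest of the two numbers in this assay; its nearest neighbour, compound 1, lies far higher, well beyond the scatter. Compound 3 `CO/N=c1/[nH]c(N)nc2c1ncn2[C@@H]1O[C@H](CO)[C@@H](O)[C@H]1O` has not been measured. Compared with compound 2 it carries amino in place of hydrogen on an aromatic carbon, placed between two ring nitrogen atoms. No step between measured compounds isolates this change, so its size is not shown directly. Because compound 1, which also carries an amino group, gives 281000 nM, a higher number than compound 2 is expected for compound 3, a moderate step beyond the scatter, a 2.9-fold higher number from compound 2 to compound 3 (0.47 log units; beyond the scatter). Compound 3 is thus estimated at 18000 nM, within 3500 nM to 90000 nM.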

Compound 3, half-maximal cytotoxic concentration: 784000 nM
The estimate for compound 3 lay 44-fold (1.64 log units) below the measured number, outside the stated range (above it).
By their numbers in this assay, from the lowest: compound 2; then compound 1; then compound 3.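

In this assay, amino in place of hydrogen on the aromatic carbon between two ring nitrogen atoms is a large change, a 130-fold higher number from compound 2 to compound 3 (2.10 log units; beyond the scatter), so much more compound is tolerated with the amino group present. With that amino group in place, methyl in place of hydrogen on an oxygen gives a much smaller step in the same direction, a 2.8-fold higher number from compound 1 to compound 3 (0.45 log units; beyond the scatter). No measurement here accounts for either step. From the compounds shown here alone, whether a methylamino group or a chlorine atom at this position would shift the number as amino does remains open, as does the effect of an ethyl group on the oxygen.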